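A Chloro-for-Methyl Step Carried to a Second Core

The source may hold more compounds than are shown below. What is called first, only, known or untested is meant among the compounds shown, and "the series" means these compounds.

Compound 1 `CC(C)=CCOc1cc(Nc2nccs2)ccc1C` and compound 2 `CC(C)=CCOc1cc(Nc2nccs2)ccc1Cl` were both measured in a functional assay on MT2 cells (Homo sapiens) for cytotoxicity, read by MTT assay; a lower number here means that less compound is tolerated, a higher number that more compound is tolerated: compound 1 gives 17000 nM and compound 2 gives 26000 nM. The change between them is chloro in place of methyl on an aromatic carbon, and the step it made was a 1.5-fold higher number from compound 1 to compound 2 (0.18 log units; within the scatter). Compound 3 `CC(C)=CCOc1cc(Nc2ncccn2)ccc1C` differs from compound 1 in its core by pyrimidin-2-yl in place of 1,3-thiazol-2-yl on a nitrogen on an aromatic ring; in this assay compound 3 gives 78000 nM, a step of a 4.6-fold higher number from compound 1 to compound 3 (0.66 log units; beyond the scatter). Compound 4 `CC(C)=CCOc1cc(Nc2ncccn2)ccc1Cl` has not yet been measured; it stands to compound 3 as compound 2 stands to compound 1, the change being (chloro in place of methyl on an aromatic carbon). This is the same kind of change, not the same one: in compound 1 the place is para to a (1,3-thiazol-2-yl)amino group (6 heavy atoms), whereas in compound 3 it is para to a group of 7 heavy atoms. Because the earlier step of a 1.5-fold higher number from compound 1 to compound 2 (0.18 log units; within the scatter) lay within the scatter, compound 4 is expected to show a step of a 1.3-fold higher number from compound 3 to compound 4 (0.11 log units; within the scatter) in this assay. The estimate for compound 4 is 100000 nM, expected to fall between 50000 nM and 200000 nM.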

Compound 4, half-maximal cytotoxic concentration: 2500 nM
Compound 4: the middle estimate sits 40-fold (1.60 log units) above what was measured, outside the stated range (below it).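

On the core of compound 3, the chloro-for-methyl change gave a 31-fold lower number from compound 3 to compound 4 (1.49 log units; beyond the scatter) in this assay, and the behaviour seen on the core of compound 1 did not carry over: the same change on two cores in this assay, a 1.5-fold higher number (0.18 log units; within the scatter) from compound 1 to compound 2 and a 31-fold lower number (1.49 log units; beyond the scatter) from compound 3 to compound 4, 48-fold (1.68 log units) apart, beyond the scatter of two such steps. With chloro present, pyrimidin-2-yl in place of 1,3-thiazol-2-yl gave a 10-fold lower number from compound 2 to compound 4 (1.02 log units; beyond the scatter), opposite in direction to the step seen with methyl present: the same change on two cores in this assay, a 4.6-fold higher number (0.66 log units; beyond the scatter) from compound 1 to compound 3 and a 10-fold lower number (1.02 log units; beyond the scatter) from compound 2 to compound 4, 48-fold (1.68 log units) apart, beyond the scatter of two such steps. Going by these compounds alone, the two changes therefore depend on each other in these four compounds, but this covers only one pair of cores and does not show why they interact or how a further core would behave.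

The compounds shown leave open whether fluoro, bromo or methoxy in that place would follow chloro on either core. They also leave open whether the interaction would persist if a shorter chain, such as ethoxy, replaced the (3-methylbut-2-en-1-yl)oxy group.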